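The compounds below may be only part of what the source reports. "The series", "measured", "known", "first", "only" and "open" are said of these compounds alone.

The three measured compounds share one core and differ only at the end of the chain. Compound 1 `CC(C)C[C@H](NC(=O)N1CCOCC1)C(=O)N[C@H](C#N)CCc1ccccc1` carries a benzyl group there; in an assay on isolated protein for displacement of a labelled ligand from cathepsin S (Homo sapiens), read by fluorescence (a lower number here means tighter binding, a higher number weaker binding), compound 1 gives 7 nM. Compound 2 `CC(C)C[C@H](NC(=O)N1CCOCC1)C(=O)N[C@H](C#N)COCc1ccccc1Cl` gives 0.3 nM, and compound 3 `CC(C)C[C@H](NC(=O)N1CCOCC1)C(=O)N[C@H](C#N)COCc1ccc(Cl)cc1` gives 2 nM. Among these three numbers compound 3 stands second highest: the step of a 3.5-fold lower number from compound 1 to compound 3 (0.54 log units; beyond the scatter) is modest, while the step of a 6.7-fold higher number from compound 2 to compound 3 (0.82 log units; beyond the scatter) runs the other way, and the step of a 23-fold lower number from compound 1 to compound 2 (1.37 log units; beyond the scatter) is large.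

Compound 4 `Cc1ccccc1COC[C@@H](C#N)NC(=O)[C@H](CC(C)C)NC(=O)N1CCOCC1` has not yet been measured. The change from compound 3 to compound 4 is 2-methylphenyl in place of 4-chlorophenyl on a saturated chain carbon bound to an oxygen on a saturated carbon. For the measured compounds named here, no measured step swaps chlorine for a methyl group, so that part of the change has no direct precedent. The step that bears on it is the swap of 4-chlorophenyl for 2-chlorophenyl, which in reverse gave a 6.7-fold higher number from compound 2 to compound 3 (0.82 log units; beyond the scatter); read forwards, it lowers the number. A somewhat smaller effect is expected here, since the group that enters is not the one measured. For compound 4 in this assay the expected step is a 3.3-fold lower number from compound 3 to compound 4 (0.52 log units; beyond the scatter). Compound 4 is estimated at 0.6 nM, with a range from 0.2 nM to 2 nM.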

Compound 4, dissociation constant: 3 nM
Beside the measured number, compound 4's estimate is 5.0-fold (0.70 log units) below it, outside the stated range (above it).
By their numbers in this assay, from the lowest: compound 2; then compounds 3 and 4 (each within the scatter of the next); then compound 1.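

Compound 4 shows that the low number of compound 2 does not follow from any small group on the ring: putting methyl in place of chloro on that aromatic carbon costs a clear amount of binding (a 10-fold higher number from compound 2 to compound 4 (1.00 log units; beyond the scatter)), so at this position the two groups are not interchangeable. For the compounds shown here, the move from 4-chlorophenyl to 2-methylphenyl leaves the result within the scatter (a 1.5-fold higher number from compound 3 to compound 4 (0.18 log units; within the scatter)), so this assay cannot separate these two rings, although the (2-methylbenzyl)oxy chain end still gives tighter binding than the benzyl end of the first compound (a 2.3-fold lower number from compound 1 to compound 4 (0.37 log units; beyond the scatter)). Nothing among the data explains why chloro and methyl differ so much here.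

The compounds shown leave open how other groups in the same place, such as 2-fluorophenyl, 2-bromophenyl or 2-methoxyphenyl, would compare with the 2-chlorophenyl of compound 2. They also leave open how a 4-methylphenyl ring would stand against 2-methylphenyl and 4-chlorophenyl, which would show whether the place of the methyl group matters as much as the place of the chloro group does.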